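A few compounds are considered here, and "the series" means these few. Any claim that something is new, unique, unknown or untested is made for them only; others in the source may bear on it.

Measured in a functional assay on SGC-7901 cells (Homo sapiens) for antiproliferative activity, read by MTT assay, with a stated time of 72 h; on this read-out lower numbers stand for stronger inhibition and higher numbers for weaker inhibition:
compound 1 `Cc1ccccc1N1CCN(C2=CC(=O)c3cccc(O)c3C2=O)CC1` gives 5300 nM
compound 2 `O=C1C=C(N2CCN(c3ccccc3)CC2)C(=O)c2c(O)ccc(O)c21` gives 2500 nM
compound 3 `O=C1C=C(N2CCC(c3ccccc3)CC2)C(=O)c2c(O)cccc21` gives 11100 nM

Compound 3 has the highest number of the three, and both other compounds lie lower by more than the scatter. Compound 4 `Cc1ccccc1C1CCN(C2=CC(=O)c3cccc(O)c3C2=O)CC1` is next, with a single change from compound 3: methyl in place of hydrogen on an aromatic carbon. This is methyl in place of hydrogen on an aromatic carbon, ortho to a large group, so phenyl becomes 2-methylphenyl. Within the data shown here, no measured pair isolates this change, so the evidence for its direction is thin. Compound 1 also carries 2-methylphenyl and gives 5300 nM, a lower number than compound 3, but the two differ elsewhere as well. A small shift toward stronger inhibition in this assay is therefore expected, and it may stay within the scatter. The expected change is a 1.4-fold lower number from compound 3 to compound 4 (0.14 log units; within the scatter). For compound 4 the estimated value is 8000 nM, with an expected range from 3500 nM to 16000 nM.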

Compound 4, half-maximal inhibitory concentration: 3900 nM
The estimate for compound 4 lay 2.1-fold (0.31 log units) above the measured number, within the range that was stated.
By their numbers in this assay, from the lowest: compounds 2, 4 and 1 (each within the scatter of the next, the first and the last beyond it); then compound 3.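

In this assay, among these compounds, the change from phenyl to 2-methylphenyl gives a 2.8-fold lower number from compound 3 to compound 4 (0.45 log units; beyond the scatter) and, being beyond the scatter, is the first step that isolates a single change. Methyl in place of hydrogen on this aromatic carbon, ortho to a large group, therefore goes with stronger inhibition in this one pair, and compound 4 and compound 1, which also carries 2-methylphenyl, lie within the scatter of each other. Nothing available accounts for the size or direction of the step.

Still open, as far as these compounds go, is how ethyl, methoxy, a fluorine atom or an amine would compare with methyl on the same aromatic carbon. The compounds shown also leave open whether the same methyl step would appear on the core of compound 2.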